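A Methyl Removed from the Side Chain of Compound 3

This account rests on a few compounds, and the source may have more. Where it says the series, first, only, none or still open, it means among the compounds named here.

Measured so far:
Compound 1, `Cc1c(OCCCCOc2ccccc2C(=O)O)ccc(C(=O)CC2CCCC2)c1C`, gives 67.1%.
Compound 2, `Cc1c(OCCCCOc2ccc(C(=O)CC(C)(C)C)c(O)c2C)cccc1C(=O)O`, gives 95.8%.
Compound 3, `COc1ccc(C(=O)O)cc1OCCCCOc1ccc(C(=O)CC(C)C)c(O)c1C`, gives 89.7%.

These three compounds were tested in an assay on HEK293 cells for positive allosteric modulation of metabotropic glutamate receptor 2 (Rattus norvegicus), read by thallium flux, with a stated time of 2.5 min; on this read-out higher numbers stand for larger maximal responses and lower numbers for smaller maximal responses. Among them compound 3 sits second on the numbers. Its closest neighbour is compound 2, whose value lies within the usual scatter of compound 3's, so the two cannot be told apart. The most distant is compound 1, which gives a clearly smaller maximal response than compound 3, a gap that lies beyond the scatter.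

Compound 4, `CCCC(=O)c1ccc(OCCCCOc2cc(C(=O)O)ccc2OC)c(C)c1O`, has not yet been measured. It differs from compound 3 in one place only: hydrogen in place of methyl on a saturated chain carbon bound to two saturated chain carbons. Going by the values given here, no measured pair here shows this exact change, so its effect must be judged from the change itself, which removes a single carbon from a short saturated chain and touches no ring, donor, acceptor or charge. Such a small trimming is expected to move the maximal response in this assay little, if at all. The step of a number 4.7 percentage points lower from compound 3 to compound 4 (within the scatter) is therefore expected to stay within the scatter. Compound 4 is expected to give 85%, within a range from 65% to 100%.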

Compound 4, largest response reached (reported as percent of maximum), in percent of the reference or control that the assay uses: 82.8%
Compound 4: the middle estimate sits 2.2 percentage points above what was measured; the range from low to high includes it.
By their numbers in this assay, from the lowest: compound 1; then compounds 4, 3 and 2 (each within the scatter of the next, the first and the last beyond it).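

Shortening isobutylcarbonyl to propylcarbonyl gives a number 6.9 percentage points lower from compound 3 to compound 4 (within the scatter) in this assay. Going by these compounds alone, this is the first pair in the set that differs in one place only, so it gives a direct reading of this change: on a saturated chain carbon bound to two saturated chain carbons, hydrogen can take the place of methyl without a difference that can be told from the scatter. No independent measurement on hand bears on this result.

As far as these compounds go, one pair speaks only for this swap on this core, so it remains unknown whether the maximal response would hold with an amine or a fluorine on that chain carbon. A longer chain in place of propyl, such as hexyl, also remains an open question.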